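A few compounds are considered here, and "the series" means these few. Any claim that something is new, unique, unknown or untested is made for them only; others in the source may bear on it.

The three compounds measured so far, with their numbers in a functional assay on NCI-H460 cells (Homo sapiens) for cytotoxicity, read by MTT assay, with a stated time of 72 h; a higher number here means a weaker inhibitor, a lower number a stronger inhibitor:

compound 1, `O=C(Nc1ccc(-n2ncc3c(C(F)(F)F)cccc32)cc1)Nc1ccc(Cl)c(C(F)(F)F)c1`, gives 1600 nM;
compound 2, `O=C(Nc1ccc(-n2ncc3c(F)cccc32)cc1)Nc1ccc(Cl)c(C(F)(F)F)c1`, gives 3400 nM;
compound 3, `Cc1cccc2c1cnn2-c1ccc(NC(=O)Nc2ccc(Cl)c(C(F)(F)F)c2)cc1`, gives 2500 nM.

All three share one core and differ only in a single group on an aromatic carbon of the fused ring system. Among them, compound 3 stands second highest of the three numbers: the step of a 1.4-fold lower number from compound 2 to compound 3 (0.13 log units; within the scatter) is within the scatter, as is the step of a 1.6-fold higher number from compound 1 to compound 3 (0.19 log units; within the scatter), so compound 3 cannot be set apart from either neighbour with confidence. Within the data shown here, only the step of a 2.1-fold higher number from compound 1 to compound 2 (0.33 log units; beyond the scatter) is modest and beyond the scatter.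

Compound 4, `O=C(Nc1ccc(-n2ncc3ccccc32)cc1)Nc1ccc(Cl)c(C(F)(F)F)c1`, takes the change (hydrogen in place of methyl on an aromatic carbon). Among the measured compounds shown here, no measured step removes a group at this position altogether; the three steps available swap one group for another there, and two of the three stay within the scatter. On that basis, in this assay the estimated step is a 1.2-fold higher number from compound 3 to compound 4 (0.08 log units; within the scatter), with the number for compound 4 expected to lean only slightly higher than that of compound 3. Compound 4 is therefore estimated at 3000 nM, within a range from 1200 nM to 7500 nM.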

Compound 4, half-maximal inhibitory concentration: 5500 nM
Compound 4: middle estimate off by 1.8-fold (0.26 log units), on the low side; the measured number falls inside the stated range.
By their numbers in this assay, from the lowest: compounds 1, 3, 2 and 4 (each within the scatter of the next, the first and the last beyond it).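

Among these compounds, compound 4 carries only hydrogen at this position, so it is the first compound here to show what the shared core does with no added group on that aromatic carbon. Going from methyl to hydrogen, as in 4-methyl-1H-indazol-1-yl to 1H-indazol-1-yl, moves the number beyond the scatter in this assay (a 2.2-fold higher number from compound 3 to compound 4 (0.34 log units; beyond the scatter)), and going from trifluoromethyl to hydrogen does the same (a 3.4-fold higher number from compound 1 to compound 4 (0.54 log units; beyond the scatter)), so among these compounds a methyl or trifluoromethyl group at this place goes with a lower number than hydrogen. Fluoro goes against any simple reading that every group helps, since the step from fluoro to hydrogen stays within the scatter (a 1.6-fold higher number from compound 2 to compound 4 (0.21 log units; within the scatter)) and the two cannot be told apart in this assay.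

No measurement given here bears on the reason for these steps. The compounds shown leave open what an amine, a methoxy group or a carboxylic acid at this place would do, and whether a longer chain such as ethyl would keep the number as low as methyl does.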